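This account rests on a few compounds, and the source may have more. Where it says the series, first, only, none or still open, it means among the compounds named here.

Measured compounds:
compound 1 `CNC(=O)c1ccc(NCc2cncn2Cc2ccc(-c3ccccc3)cc2)cc1-c1ccccc1` — > 1000 nM
compound 2 `COc1ccc(NCc2cncn2Cc2ccc(-c3ccccc3)cc2)cc1-c1ccccc1` — > 1000 nM

In a toxicity assay on NIH3T3 cells (Mus musculus) for cytotoxicity, read by resazurin assay (on this read-out lower numbers stand for an effect already at smaller amounts and higher numbers for an effect only at larger amounts of compound), compound 1 gives > 1000 nM, which is a limit of the assay and not a number. Compound 2 stands at > 1000 nM, again only a limit. The step that the two limits leave unreadable from compound 1 to compound 2 cannot be read, since both values rest at the limit of > 1000 nM in this assay, at which 2 of the 2 values shown sit. Compound 3 `CCOC(=O)c1ccc(NCc2cncn2Cc2ccc(-c3ccccc3)cc2)cc1-c1ccccc1` differs from compound 2 by ethoxycarbonyl in place of methoxy on an aromatic carbon. No readable measured step bears on this change, so compound 3 is expected to remain at the limit, with the step that the limit leaves unreadable from compound 2 to compound 3 expected to stay within the scatter. The estimate for compound 3 is 3000 nM, in a range from 1000 nM to 10000 nM.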

Compound 3, half-maximal effective concentration: > 10000 nM
Compound 3 ended at the assay's limit (the forecaster's own chance of this, stated with the estimate: 80%); middle value at least 3.3-fold (0.52 log units) from the limit.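

Among these compounds, the values of compound 1, compound 2 and compound 3 are all limits of the assay and not numbers, so no step among them can be read. What remains open is at what concentration any of these compounds produces an effect, and whether exchanging these groups changes it.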